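From pent-4-yn-1-yl to hex-5-yn-1-yl on the shared core

This account rests on a few compounds, and the source may have more. Where it says the series, first, only, none or still open, it means among the compounds named here.

Compound 1 `CCCCCc1cc2cn([C@H]3C[C@H](O)[C@@H](CO)O3)c(=O)nc2o1` and compound 2 `C#CCCCc1cc2cn([C@H]3C[C@H](O)[C@@H](CO)O3)c(=O)nc2o1` share a core and differ in their side chains. In a functional assay on HEL cells (Homo sapiens) for cytotoxicity (a higher number here means that more compound is tolerated, a lower number that less compound is tolerated), compound 1 gives > 50000 nM, which is a limit of the assay and not a number. Compound 2 gives > 200000 nM, again only a limit, so it has no exact position on the scale.

Compound 3 `C#CCCCCc1cc2cn([C@H]3C[C@H](O)[C@@H](CO)O3)c(=O)nc2o1` is compound 2 with one change: propargyl in place of ethynyl on a saturated chain carbon, three bonds along the chain from an aromatic carbon. Propargyl stands in place of ethynyl on a saturated chain carbon, three bonds along the chain from an aromatic carbon, so pent-4-yn-1-yl becomes hex-5-yn-1-yl.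

Among the compounds with values here, only one measured step bears on this change, and it offers no size to carry over because a step that the two limits leave unreadable from compound 1 to compound 2 is all that the data give. With no measured size or direction to build on, no shift beyond the usual scatter is expected in this assay. The expected change is an at least 1.3-fold lower number from compound 2 to compound 3 (0.12 log units; that floor lies within the scatter). Compound 3 is estimated at 150000 nM, with an expected range from 50000 nM to 300000 nM.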

Compound 3, half-maximal cytotoxic concentration: > 200000 nM
Compound 3 was reported as a limit (the forecaster's own chance of this, stated with the estimate: 70%); middle value at least 1.3-fold (0.12 log units) from the limit.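

No step among compound 1, compound 2 and compound 3 can be read in this assay, because each reported value is a limit and not a number: the limit of > 200000 nM in this assay, at which 2 of the 3 values shown sit.

The compounds shown leave open where any of the three sits on the scale, and whether going from pent-4-yn-1-yl to hex-5-yn-1-yl changes the tolerated concentration at all.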